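This account rests on a few compounds, and the source may have more. Where it says the series, first, only, none or still open, it means among the compounds named here.

Working notes on the series.

Of the compounds shown here, two have numbers so far. Compound 1 `C=CCn1ccc(N2C[C@H](COC)OC2=O)c1` carries the allyl on the aromatic nitrogen and a methoxymethyl on the oxazolidinone; in an assay for inhibition of Amine oxidase [flavin-containing] A (Bos taurus), read by fluorescence, with a stated time of 30 min (a lower number here means a stronger inhibitor, a higher number a weaker inhibitor), compound 1 gives 1 nM. Compound 2 `CCn1ccc(N2C[C@H](CNC)OC2=O)c1` carries an ethyl on the aromatic nitrogen and a methylaminomethyl on the oxazolidinone; in this assay compound 2 gives 80 nM. Compound 2 therefore stands at the higher of the two numbers, and its gap to compound 1 lies beyond the scatter. Compound 1 and compound 2 differ in two places at once, so their two values say nothing on their own about either change.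

Compound 3 `C=CCn1ccc(N2C[C@H](CNC)OC2=O)c1` is not yet measured. It differs from compound 2 in one place: vinyl in place of methyl on a saturated chain carbon bound to an aromatic nitrogen. Among the measured compounds shown here, no measured pair shows this change alone. On that basis a step from compound 2 to compound 3 of a 2.7-fold lower number from compound 2 to compound 3 (0.43 log units; beyond the scatter) is expected in this assay, towards a lower number, since the allyl is the group compound 1 carries on that nitrogen, but with wide uncertainty. For compound 3 the estimate in this assay is 30 nM, with a range from 8 nM to 120 nM.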

Compound 3, inhibition constant: 100 nM
The estimate for compound 3 lay 3.3-fold (0.52 log units) below the measured number; low and high end bracket the measured number.
By their numbers in this assay, from the lowest: compound 1; then compounds 2 and 3 (each within the scatter of the next).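

Read alone for the first time, vinyl in place of methyl on a saturated chain carbon bound to an aromatic nitrogen gives a 1.3-fold higher number from compound 2 to compound 3 (0.10 log units; within the scatter) in this assay, so with methylamino held constant, the change from ethyl to allyl does not separate the two compounds. The large gap in this series now has a single-change reading at the other place: methylamino in place of methoxy on a saturated chain carbon bound to a saturated ring carbon gives a 100-fold higher number from compound 1 to compound 3 (2.00 log units; beyond the scatter), with the allyl held constant. No evidence on hand bears on what lies behind either step.

Among the compounds shown here, the ethyl to allyl step is read only alongside methylamino, and methoxy is seen only with allyl, so it remains open whether the same small step would hold alongside methoxy. Also open, as far as these compounds go, is how the large step would read with other groups at that place, such as a hydroxyl or a dimethylamino group, and whether a longer chain such as butyl on the aromatic nitrogen would stay within the scatter of ethyl and allyl.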